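Swapping chloro for cyano: a cytotoxicity estimate

The compounds below may be only part of what the source reports. "The series", "measured", "known", "first", "only" and "open" are said of these compounds alone.

Three compounds have been measured in an ADME assay on MT2 cells (Homo sapiens) for cytotoxicity; on this read-out lower numbers stand for higher toxicity in this test and higher numbers for lower toxicity in this test:
Compound 1, `CC(C)=CCOc1cc(Nc2ncnc(Cl)n2)ccc1Cl`, gives 45000 nM.
Compound 2, `CC(C)=CCOc1cc(Nc2ncnc(Cl)n2)ccc1C#N`, gives > 100000 nM, which is a limit of the assay rather than a number.
Compound 3, `COc1ccnc(Nc2ccc(Cl)c(OCC=C(C)C)c2)n1`, gives 9000 nM.

Compound 1 and compound 2 differ by cyano in place of chloro on an aromatic carbon, and this gave an at least 2.2-fold higher number from compound 1 to compound 2 (0.34 log units; beyond the scatter). Its true size is not known, since it rests on (the limit of > 100000 nM in this assay, at which 1 of the 3 values shown sits). Compound 3 and compound 1 differ in more than one place; that difference between the two cores is not broken down here. Compound 4, `COc1ccnc(Nc2ccc(C#N)c(OCC=C(C)C)c2)n1`, is not yet measured. It differs from compound 3 by cyano in place of chloro on an aromatic carbon. The surroundings differ slightly: in compound 3 the site is para to a group of 9 heavy atoms, in compound 1 para to a group of 8 heavy atoms, so this is the same kind of change, not the same change. Guided by compound 1 and compound 2, an at least 2.2-fold higher number from compound 1 to compound 2 (0.34 log units; beyond the scatter), a similar rise is expected, estimated as a 3.0-fold higher number from compound 3 to compound 4 (0.48 log units; beyond the scatter). Compound 4 is therefore expected to give about 27000 nM in this assay, plausibly between 12000 nM and 100000 nM.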

Compound 4, half-maximal cytotoxic concentration: 230 nM
The estimate for compound 4 lay 120-fold (2.07 log units) above the measured number; measured number outside the range, below it.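

In this assay, putting cyano in place of chloro gave a 39-fold lower number from compound 3 to compound 4 (1.59 log units; beyond the scatter), so the change did not carry over from one core to the other and its direction reversed: the same change on two cores in this assay, an at least 2.2-fold higher number (0.34 log units; beyond the scatter) from compound 1 to compound 2 and a 39-fold lower number (1.59 log units; beyond the scatter) from compound 3 to compound 4, at least 86-fold (1.93 log units) apart, beyond the scatter of two such steps. Compound 2 gives a limit of the assay and not a number, so the earlier step has no exact size: the limit of > 100000 nM in this assay, at which 1 of the 4 values shown sits. In this series, then, the step seen on one core was a poor guide to the same change on the other, but two pairs neither explain the difference nor set a rule for other cores.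

The compounds shown leave open how this swap behaves on any further core. They also leave open what an amine or a carboxylic acid at the same place would give on the core of compound 3.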